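A Shorter Amine on a Longer Chain

The compounds below may be only part of what the source reports. "The series", "measured", "known", "first", "only" and "open" are said of these compounds alone.

Of the compounds shown here, two sharing one core have been measured so far. Compound 1 `COc1c(OCCCCN2CCN(C)CC2)cc(O)c2c(=O)cc(-c3ccc(C(F)(F)F)cc3)oc12` gives 2400 nM in a functional assay on HepG2 cells (Homo sapiens) for cytotoxicity, read by MTT assay, with a stated time of 72 h; on this read-out higher numbers stand for weaker inhibition and lower numbers for stronger inhibition. Compound 2 `CCN(CC)CCCOc1c(OCc2ccccc2)cc(O)c2c(=O)cc(-c3ccccc3)oc12` gives 3010 nM in this assay; the two values lie within the usual scatter of one another, so neither stands apart from the other. Compound 3 `CN(C)CCCCOc1c(OCc2ccccc2)cc(O)c2c(=O)cc(-c3ccccc3)oc12` has not yet been measured. It differs from compound 2 in one place: (dimethylamino)methyl in place of diethylamino on a saturated chain carbon, three bonds along the chain from an oxygen on an aromatic ring. For the measured compounds named here, no step between measured compounds is available, so nothing measured here shows how such a change acts. The change keeps a nitrogen at the end of the side chain and only shifts carbons around it, which gives no reason to expect a step beyond the scatter in either direction. The step expected from compound 2 to compound 3 is a 1.0-fold lower number from compound 2 to compound 3 (0.00 log units; within the scatter). Compound 3 is therefore expected to give about 3000 nM in this assay, most likely between 1200 nM and 7500 nM.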

Compound 3, half-maximal inhibitory concentration: 2090 nM
Estimate against measurement, compound 3: 1.4-fold (0.16 log units) above; low and high end bracket the measured number.
By their numbers in this assay, from the lowest: compounds 3, 1 and 2 (each within the scatter of the next).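

For the compounds shown here, this is the first measured step at this position on the side chain. In this assay, putting (dimethylamino)methyl in place of diethylamino gives a small difference (a 1.4-fold lower number from compound 2 to compound 3 (0.16 log units; within the scatter)), so the position tolerates this swap without a step beyond the scatter. Read one bond further out, the same change turns 3-(diethylamino)propyl into 4-(dimethylamino)butyl, so the chain end and the groups on the nitrogen differ together, and this one pair shows that the two differences taken together leave the number within the scatter. No measured evidence here explains the result.

The compounds shown leave open what each difference does alone, which a 4-(diethylamino)butyl or a 3-(dimethylamino)propyl chain on the same core would separate. They also leave open whether a ring amine such as morpholine or pyrrolidine at the chain end would give a step beyond the scatter.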